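A few compounds are considered here, and "the series" means these few. Any claim that something is new, unique, unknown or untested is made for them only; others in the source may bear on it.

Measured compounds:
- compound 1, `Cc1cccc(C)c1CN[C@]1(CCC(C)(C)C)C(=O)C(C2=NS(=O)(=O)c3cc(NS(C)(=O)=O)ccc3N2)=C(O)c2ccccc21`: 11.7 mL/min/kg
- compound 2, `CC(C)CC[C@@]1(NCc2ccccc2)C(=O)C(C2=NS(=O)(=O)c3cc(NS(C)(=O)=O)ccc3N2)=C(O)c2ccccc21`: 19.3 mL/min/kg

In an in vivo ADME assay on the whole organism (strain Sprague-Dawley) for pharmacokinetics, with Rattus norvegicus as the target, at a dose of 5 mg/kg by the intravenous route (a lower number here means slower removal, a higher number faster removal of the compound), compound 1 gives 11.7 mL/min/kg, and compound 2 gives 19.3 mL/min/kg. The two values lie within the scatter of each other, so compound 1 stands at one end of the pair without being separable from compound 2. Among the measured compounds shown here, no step between compounds differing in one place is available here.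

Compound 3, `Cc1cccc(C)c1CNC1(CCC(C)(C)C)C(=O)C(C2=NS(=O)(=O)c3cc(NS(C)(=O)=O)ccc3N2)=C(O)c2ccccc21`, has not been measured in this assay . It differs from compound 1 in this way: the two compounds have the same atoms and bonds; at least one stereo element is drawn with a configuration in one of them and without one in the other: 1 of 1 stereo elements differ; a stereocentre at a saturated ring carbon is drawn S in compound 1 and without a configuration in compound 3. Since the atoms and bonds are identical and only the drawn configuration at the stereocentre is absent, any step is expected to be small and without a preferred direction, most likely none beyond the scatter. The step from compound 1 to compound 3 is therefore estimated as a 1.1-fold higher number from compound 1 to compound 3 (0.05 log units; within the scatter). Compound 3 is expected to give about 13 mL/min/kg, within a range from 7 mL/min/kg to 26 mL/min/kg.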

Compound 3, clearance: 13 mL/min/kg
Compound 3: middle estimate and measured number agree at the digits printed, within the range that was stated.
By their numbers in this assay, from the lowest: compounds 1, 3 and 2 (each within the scatter of the next).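

Compounds 1 and 2 differ in more than one place, so they could not isolate any single feature, whereas compounds 1 and 3 share all atoms and bonds. In this assay, the comparison gives a 1.1-fold higher number from compound 1 to compound 3 (0.05 log units; within the scatter), so dropping the drawn S configuration at the saturated ring carbon leaves clearance indistinguishable within the scatter. With atoms and bonds identical, this step can be attached to one structural difference only: the fact that one of compounds 1 and 3 is drawn with a defined configuration and the other without, at the place where they differ

The compounds shown leave open how a compound drawn with the opposite configuration at this stereocentre alone would behave, since compound 3 carries no drawn configuration there. They also leave open whether a carboxylic acid or a longer chain on the shared core would shift clearance beyond the scatter.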